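Furan in Place of Methoxyphenyl on the Amide Arm

The compounds below may be only part of what the source reports. "The series", "measured", "known", "first", "only" and "open" are said of these compounds alone.

Among the compounds with values here, the three compounds measured so far share a core bearing an amide and an amine-linked side chain, all tested in a functional assay on HCT-116 cells (Homo sapiens) for cytotoxicity, read by MTT assay, with a stated time of 72 h; a lower number here means a stronger inhibitor, a higher number a weaker inhibitor. Compound 1 `COc1cccc(CNC(=O)c2nc(Br)c3cccnc3c2N[C@H]2CC[C@H](N)CC2)c1` gives 6000 nM in this assay, the lowest of the two numbers reported. Compound 3 `CS(=O)(=O)NCCCN(c1nc(C(=O)NCc2ccc(F)cc2)c(O)c2ncccc12)S(C)(=O)=O` gives 15000 nM, and the gap between the two lies beyond the usual scatter. For compound 2 `O=C(NCc1ccc(F)cc1)c1nc(Br)c2cccnc2c1NCc1ccccc1` this assay reports only a limit, > 20000 nM, so no number is known for it; (the limit of > 20000 nM in this assay, at which 1 of the 3 values shown sits).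

Compound 4 `N[C@H]1CC[C@H](Nc2c(C(=O)NCc3ccco3)nc(Br)c3cccnc23)CC1` differs from compound 1 in a single respect: furan-2-yl in place of 3-methoxyphenyl on a saturated chain carbon bound to an amide-type nitrogen. Within the data shown here, no step between two measured compounds is reported, so nothing in the data anchors the size of this exchange. The expected step of a 1.3-fold higher number from compound 1 to compound 4 (0.12 log units; within the scatter) is therefore small, a modest move toward weaker inhibition that stays within the scatter. Compound 4 is expected to give 8000 nM in this assay, with a range from 3000 nM to 20000 nM.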

Compound 4, half-maximal inhibitory concentration: > 10000 nM
Compound 4: a limit, no number; the forecaster's own chance of this, stated with the estimate: 15%; at least 1.2-fold (0.09 log units) between middle value and limit.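

Furan-2-yl in place of 3-methoxyphenyl on a saturated chain carbon bound to an amide-type nitrogen gives the only one-place step shown in this assay: an at least 1.6-fold higher number from compound 1 to compound 4 (0.22 log units; that floor lies within the scatter). Compound 4 carries a limit and not a number: the limit of > 10000 nM in this assay, at which 1 of the 4 values shown sits. The exchange therefore brings no gain over compound 1 at this place, but only a floor is known, so the true size of the step may lie within the scatter or beyond it.

The compounds shown leave open how a pyridine ring, or a longer chain ending in the 3-methoxyphenyl, would read at this place. Within the data shown here, compound 2 and compound 3 differ from compound 1 in more than one place, so they add no second step at this position.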